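This account rests on a few compounds, and the source may have more. Where it says the series, first, only, none or still open, it means among the compounds named here.

In a functional assay on U-937 cells (Homo sapiens) for cytotoxicity, read by MTT assay, with a stated time of 48 h (on this read-out lower numbers stand for stronger inhibition and higher numbers for weaker inhibition), compound 2 `Fc1cccc(-c2nc(Nc3ccccc3F)c3cc(F)ccc3n2)c1` reaches only the limit of the assay, > 50000 nM. Compound 1 `Fc1ccc(Nc2nc(-c3cccc(F)c3)nc3ccc(F)cc23)cc1` likewise gives a limit, > 50000 nM. Compound 3 `Fc1cccc(-c2nc(Nc3ccccc3Cl)c3cc(F)ccc3n2)c1` also stops at a limit, > 50000 nM. The steps a step that the two limits leave unreadable from compound 1 to compound 2, a step that the two limits leave unreadable from compound 1 to compound 3 and a step that the two limits leave unreadable from compound 2 to compound 3 therefore cannot be read, since every value sits at the limit of > 50000 nM in this assay, at which 3 of the 3 values shown sit. Compound 4 `Cc1ccc(Nc2nc(-c3cccc(F)c3)nc3ccc(F)cc23)cc1` differs from compound 2 by 4-methylphenyl in place of 2-fluorophenyl on a nitrogen on an aromatic ring. Going by the values given here, none of the measured steps carries a readable size that bears on this change, so no direction beyond the scatter can be expected from them. Compound 4 is expected to stay near the limit, with an estimated 50000 nM, between 15000 nM and 150000 nM. The step expected is a number no higher from compound 2 to compound 4 (the limit leaves the size open), most likely reported once more only as a limit.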

Compound 4, half-maximal inhibitory concentration: > 50000 nM
Compound 4 gave a limit, no number; the forecaster's own chance of this, stated with the estimate: 85%; the middle value sits exactly at the limit.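

No step linking compound 4 to compound 1, compound 2 or compound 3 can be read, because all four stop at a limit: the limit of > 50000 nM in this assay, at which 4 of the 4 values shown sit.

The compounds shown leave open how the groups on the nitrogen rank, and whether any change to the shared core gives a readable number.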